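A few compounds are considered here, and "the series" means these few. Any claim that something is new, unique, unknown or untested is made for them only; others in the source may bear on it.

Compound 1, `Cn1nnnc1SCC(=O)N/N=C/c1ccc(Br)cc1`, compound 2, `Cn1nnnc1SCC(=O)N/N=C/c1ccc(O)cc1`, and compound 3, `Cn1nnnc1SCC(=O)N/N=C/c1ccccc1Br`, were all tested in a functional assay on A549 cells (Homo sapiens) for cytotoxicity, read by XTT assay, with a stated time of 24 h; a higher number here means a weaker inhibitor, a lower number a stronger inhibitor. For compound 1 the result is only a limit of the assay, > 10000000 nM. For compound 2 the result is likewise only a limit, > 10000000 nM. Compound 3 is the single one of the three to give a number: in this assay compound 3 gives 2000000 nM. The change from compound 1 to compound 2 is hydroxy in place of bromo on an aromatic carbon, and its step, a step that the two limits leave unreadable from compound 1 to compound 2, cannot be sized because the limit of > 10000000 nM in this assay, at which 2 of the 3 values shown sit, is where both of those values rest. How the core of compound 3 differs from that of compound 1 is not broken down here; the two share the same atoms joined differently.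

Compound 4, `Cn1nnnc1SCC(=O)N/N=C/c1ccccc1O`, has not been measured in this assay. It relates to compound 3 through (hydroxy in place of bromo on an aromatic carbon). This is the same kind of change as that from compound 1 to compound 2, though not the same: there the hydroxy enters para to a large group, here ortho to a large group. Since the earlier step is unreadable, the expectation for compound 4 rests mainly on compound 3 and its value 2000000 nM, with the reading that a hydroxy in place of bromo is not expected to add potency. Compound 4 is therefore expected to give about 5000000 nM in this assay, a step of a 2.5-fold higher number from compound 3 to compound 4 (0.40 log units; beyond the scatter), and it is expected to lie between 1000000 nM and 20000000 nM, with a real chance that only a limit is reported.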

Compound 4, half-maximal inhibitory concentration: > 10000000 nM
Compound 4 was reported as a limit; the forecaster's own chance of this, stated with the estimate: 55%; at least 2.0-fold (0.30 log units) between middle value and limit.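

From the compounds shown here alone, on the core of compound 3, with the group ortho to a large group, hydroxy in place of bromo gives an at least 5.0-fold higher number from compound 3 to compound 4 (0.69 log units; beyond the scatter) in this assay, so on this core the change goes with a weaker result, and the true size of the step remains open on the upper side, since compound 4 gives > 10000000 nM, which is a limit of the assay and not a number. Among the compounds shown here, the same change on the core of compound 1 cannot be read, as compound 1 and compound 2 are both reported only as limits, so the series shows the change with a readable size on one core only and gives no second step to set beside it. Whether the change carries from one core to the other therefore stays undecided, and no agreement or disagreement between the two steps can be claimed, because the comparison ends at the same ceiling: the limit of > 10000000 nM in this assay, at which 3 of the 4 values shown sit.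

The compounds shown leave open whether any other group in place of bromo on the core of compound 3, such as a methoxy, an amine or a carboxylic acid, would stay on the scale of the assay. They also leave open whether a chloro or a methyl there would give a number close to that of compound 3, which gives 2000000 nM.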